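The compounds below may be only part of what the source reports. "The series", "measured", "known", "first", "only" and "open" are said of these compounds alone.

Measured compounds:
Compound 1, `Cc1ccc2[nH]c(SCC(=O)N3CCC[C@H]3C(=O)Nc3ccccc3-n3cccc3)nc2c1`, gives 3 nM in an assay on CHO cells for displacement of a labelled ligand from Orexin/Hypocretin receptor type 1 (Homo sapiens); a higher number here means a weaker inhibitor, a lower number a stronger inhibitor.
Compound 2, `Cn1c(CCC(=O)N2CCC[C@H]2C(=O)Nc2ccccc2-c2ccccc2)nc2ccccc21`, gives 15 nM in this assay.
Compound 3, `Cc1ccc2c(c1)nc(SCC(=O)N1CCC[C@H]1C(=O)Nc1ccccc1-n1cccc1)n2C`, gives 0.7 nM in this assay.

Compound 3 and compound 1 share a core and differ only by hydrogen in place of methyl on an aromatic nitrogen; that change gave a 4.3-fold higher number from compound 3 to compound 1 (0.63 log units; beyond the scatter). Compound 2 has the highest number of the three, and the difference between its core and that of compound 3 is not broken down here. Compound 4, `O=C(Nc1ccccc1-c1ccccc1)[C@@H]1CCCN1C(=O)CCc1nc2ccccc2[nH]1`, is not yet measured; it differs from compound 2 by hydrogen in place of methyl on an aromatic nitrogen, the same change as before, made at the same kind of place. The step from compound 2 to compound 4 is expected to be a 4.0-fold higher number from compound 2 to compound 4 (0.60 log units; beyond the scatter) because the earlier step of a 4.3-fold higher number from compound 3 to compound 1 (0.63 log units; beyond the scatter) points that way. Compound 4 is therefore estimated at 60 nM in this assay, with an expected range from 20 nM to 200 nM.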

Compound 4, inhibition constant: 40 nM
Estimate against measurement, compound 4: 1.5-fold (0.18 log units) above; measured number inside the range.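

Putting hydrogen in place of the methyl on the aromatic nitrogen gave a 2.7-fold higher number from compound 2 to compound 4 (0.43 log units; beyond the scatter) in this assay. Set beside the earlier step, the change keeps its direction and the two sizes do not differ meaningfully: the same change on two cores in this assay, a 4.3-fold higher number (0.63 log units; beyond the scatter) from compound 3 to compound 1 and a 2.7-fold higher number (0.43 log units; beyond the scatter) from compound 2 to compound 4, 1.6-fold (0.21 log units) apart, within the scatter of two such steps. On these two cores, then, the step carries over, but two pairs cannot show that it would hold on a further core, nor why hydrogen gives the higher number.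

The compounds shown carry only methyl or hydrogen on that nitrogen. Going by these compounds, what a longer chain such as ethyl, or a chain ending in an amine or a carboxylic acid, would do there remains open.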